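The compounds below may be only part of what the source reports. "The series", "measured", "known", "first", "only" and "open" are said of these compounds alone.

Working notes on the series. Compound 1, `CC(O)(C(=O)Nc1ccc(S(=O)(=O)c2ccccc2)c(O)c1)C(F)(F)F`, carries a hydroxy on the shared core. In a functional assay (Cavia porcellus) with sulfonylurea receptors; K-ATP channels (Homo sapiens) as the target (a higher number here means a weaker inhibitor, a lower number a stronger inhibitor), compound 1 gives 430 nM. For the measured compounds named here, compound 2, `CC(O)(C(=O)Nc1ccc(S(=O)(=O)c2ccc(Br)cc2)cc1)C(F)(F)F`, differs from compound 1 in more than one place and offers no single step. In this assay compound 2 returns only a limit of the assay, > 30000 nM, and no number. Of the numbers shown, compound 1 therefore stands as the only actual value; the other entry is the limit of > 30000 nM in this assay, at which 1 of the 2 values shown sits. Going by the values given here, no step between measured compounds that differ in one place is at hand, so any view of compound 3 rests on the structural change alone.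

Compound 3, `CC(O)(C(=O)Nc1ccc(S(=O)(=O)c2ccccc2)c(C(=O)O)c1)C(F)(F)F`, carries carboxy in place of hydroxy on an aromatic carbon, carboxy in place of hydroxy on an aromatic carbon. Nothing measured in this series tells how this assay answers such an exchange. The expected step is a 3.5-fold higher number from compound 1 to compound 3 (0.54 log units; beyond the scatter), in the weaker direction and beyond the scatter, with wide uncertainty attached. Compound 3 is accordingly estimated at 1500 nM in this assay, within a range of 300 nM to 8000 nM.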

Compound 3, half-maximal inhibitory concentration: > 30000 nM
Compound 3 was reported as a limit; the forecaster's own chance of this, stated with the estimate: 15%; at least 20-fold (1.30 log units) between middle value and limit.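

For the compounds shown here, this position on the shared core, an aromatic carbon ortho to a group of 9 heavy atoms and meta to a large group, proves sensitive in this assay: carboxy in place of hydroxy gives an at least 69-fold higher number from compound 1 to compound 3 (1.84 log units; beyond the scatter), the first step that can be read. Compound 3 is reported only as a limit of the assay, > 30000 nM, and the step therefore gives a minimum size rather than a measured one: the limit of > 30000 nM in this assay, at which 2 of the 3 values shown sit. Hydroxy and carboxy are counted alike in hydrogen-bond donors, hydrogen-bond acceptors and net charge, so these counts do not separate them, whereas the heavy atoms and the double bond outside aromatic rings do differ.

From the compounds shown here alone, how a methoxy, an amine or a carboxamide on this aromatic carbon would read in this assay remains open. Only hydroxy and carboxy can be compared at this position, which leaves open whether the large step is particular to carboxy or extends to other groups there.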